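A few compounds are considered here, and "the series" means these few. Any claim that something is new, unique, unknown or untested is made for them only; others in the source may bear on it.

Series notes, biphenyl amide set.

The shared core carries a three-membered ring bearing an aromatic group, and the aromatic group is the point of variation. Compound 1 `CC[C@H](C)[C@H](N)CN(C(=O)[C@@H]1C[C@H]1c1ccccc1)c1ccc(-c2ccccc2)cc1` is the parent with an unsubstituted phenyl; in a functional assay for agonist activity at G protein-coupled receptor 88 (Homo sapiens), read by HTRF and cAMP accumulation (a higher number here means that more compound is needed for the effect, a lower number that less compound is needed), compound 1 gives 230 nM; 800 nM (2 entries), and the spread between those entries is itself a caution on how far any single number can be read, as seen in the several entries of compound 1 in this assay, 230 nM; 800 nM (2 entries). Compound 2 `CC[C@H](C)[C@H](N)CN(C(=O)[C@@H]1C[C@H]1c1cc(F)cc(F)c1)c1ccc(-c2ccccc2)cc1` carries the 3,5-difluorophenyl; in this assay compound 2 gives 960 nM, which is the only number shown for it, with one further entry that did not yield a single number. Set against the entries of compound 1, the value of compound 2 sits at the weaker end of that range.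

Compound 3 `CC[C@H](C)[C@H](N)CN(C(=O)[C@@H]1C[C@H]1c1nc(C)cs1)c1ccc(-c2ccccc2)cc1` replaces the aromatic group again: 4-methyl-1,3-thiazol-2-yl in place of 3,5-difluorophenyl on a saturated ring carbon. Within the data shown here, no measured step of this kind is in hand, so the expectation rests on the spread of compounds 1 and 2. The step of a 1.6-fold higher number from compound 2 to compound 3 (0.19 log units; within the scatter) is expected to be small, toward more compound needed, and may not exceed the scatter. Compound 3 is estimated at 1500 nM in this assay, within 500 nM to 5000 nM.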

Compound 3, half-maximal effective concentration: 730 nM
The estimate for compound 3 lay 2.1-fold (0.31 log units) above the measured number; the measured number falls inside the stated range.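

Among these compounds, on the saturated ring carbon of the three-membered ring, 4-methyl-1,3-thiazol-2-yl in place of 3,5-difluorophenyl gives a 1.3-fold lower number from compound 2 to compound 3 (0.12 log units; within the scatter) in this assay, and this is the only measured step at this position so far. It shows that a five-membered aromatic ring with 2 hetero atoms and 2 hydrogen-bond acceptors can stand here in place of a six-membered aromatic ring of carbon only, with no difference that can be told from the scatter. The entries of the parent also caution against reading this step any more finely: the several entries of compound 1 in this assay, 230 nM; 800 nM (2 entries)

Every group shown at this position is aromatic, so it stays open whether an amine, a carboxylic acid or a longer alkyl chain on the same ring carbon would keep the agonist activity. Also open, going by these compounds, is what an unsubstituted 1,3-thiazol-2-yl would give set against compound 3, and with it whether the methyl group on that ring matters at all.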